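A 2-cyanophenyl group replaces 4-fluorophenyl

The source may report more compounds than this note shows. Statements on the series, on what has been measured and on what is new or still open speak of the compounds shown alone.

In a functional assay on HT-29 cells (Homo sapiens) for inhibition, read by CCK-8 assay, with a stated time of 24 h (on this read-out higher numbers stand for weaker inhibition and lower numbers for stronger inhibition), three compounds with a shared core differ only in the phenyl group on an aromatic nitrogen. Compound 1 `Cc1ccccc1-n1cc(-c2ccc(/C=C3\C(=O)Nc4ccccc43)cc2)nn1` with 2-methylphenyl stands at 8710 nM and compound 2 `Cc1cccc(-n2cc(-c3ccc(/C=C4\C(=O)Nc5ccccc54)cc3)nn2)c1` with 3-methylphenyl stands at 3940 nM on this scale. Compound 3 `O=C1Nc2ccccc2/C1=C/c1ccc(-c2cn(-c3ccc(F)cc3)nn2)cc1` with 4-fluorophenyl reaches 17700 nM which is the highest number of the three and so the weakest inhibition among them.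

Compound 4 `N#Cc1ccccc1-n1cc(-c2ccc(/C=C3\C(=O)Nc4ccccc43)cc2)nn1` has not yet been measured. It carries 2-cyanophenyl in place of 4-fluorophenyl on the same aromatic nitrogen. The change is 2-cyanophenyl in place of 4-fluorophenyl on an aromatic nitrogen and it sits on a five-membered aromatic ring with 3 nitrogen.

The measured swaps at this place bear on it, and all of them were modest. There is a 2.0-fold higher number from compound 1 to compound 3 (0.31 log units; beyond the scatter) and a 4.5-fold higher number from compound 2 to compound 3 (0.65 log units; beyond the scatter) and also a 2.2-fold lower number from compound 1 to compound 2 (0.34 log units; beyond the scatter) between the two methylphenyl groups. Among the measured compounds shown here, compound 1 at 8710 nM is the nearest of these to compound 3, so a modest step toward a lower number is expected in this assay although no measured compound carries a nitrile. The expected change is a 2.0-fold lower number from compound 3 to compound 4 (0.29 log units; within the scatter) by this estimate. For compound 4 the estimated value is 9000 nM with an expected range from 3500 nM to 20000 nM in this measurement.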

Compound 4, half-maximal inhibitory concentration: 14400 nM
The estimate for compound 4 lay 1.6-fold (0.20 log units) below the measured number, and the stated range covers the measured number.
By their numbers in this assay, from the lowest: compound 2; then compounds 1, 4 and 3 (each within the scatter of the next, the first and the last beyond it).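

In this assay, 2-cyanophenyl in place of 4-fluorophenyl gives a 1.2-fold lower number from compound 3 to compound 4 (0.09 log units; within the scatter), so these two groups cannot be told apart at this position, even though only 2-cyanophenyl carries a nitrile and a hydrogen-bond acceptor. Cyano in place of methyl on an aromatic carbon, the only difference between the next two compounds, gives a 1.7-fold higher number from compound 1 to compound 4 (0.22 log units; within the scatter), so bringing a nitrile into the series also leaves no readable difference from 2-methylphenyl. Against this, 2-cyanophenyl in place of 3-methylphenyl gives a 3.7-fold higher number from compound 2 to compound 4 (0.56 log units; beyond the scatter), and since the steps from compound 2 to each of the other three compounds all lie beyond the scatter, compound 2 remains the strongest inhibitor of the four in this assay.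

Nothing measured here explains why 3-methylphenyl stands apart from the other three groups. The compounds shown also leave open how this position would respond to an amine or a carboxylic acid on the phenyl ring in place of the nitrile, and whether either would move the number further than the methyl, fluoro and cyano groups have.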